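The source may report more compounds than this note shows. Statements on the series, on what has been measured and on what is new or still open speak of the compounds shown alone.

For the measured compounds named here, compound 1 (`CC(C)=CCC/C(C)=C/Cc1c(O)cc2c(c1O)C(=O)C[C@@H](c1cc(O)cc(O)c1)O2`) gives 8500 nM in a functional assay on THP-1 cells (Homo sapiens) for cytotoxicity, with a stated time of 72 h (a higher number here means that more compound is needed for the effect, a lower number that less compound is needed), and so holds the only exact number among the compounds measured so far. The reading for compound 2 (`COc1cc(O)c([C@@H]2CC(=O)c3c(O)cc(O)cc3O2)cc1C/C=C(\C)CCC=C(C)C`) in this assay is a limit: > 10000 nM is all that is reported. Compound 3 (`CC(C)=CCC/C(C)=C/Cc1c(O)cc2c(c1O)C(=O)C[C@@H](c1ccc(O)c(O)c1)O2`) has not yet been measured. It keeps the core of compound 1 but carries 3,4-dihydroxyphenyl in place of 3,5-dihydroxyphenyl on a saturated ring carbon, next to the ring oxygen (3,4-dihydroxyphenyl in place of 3,5-dihydroxyphenyl on a saturated ring carbon). Going by the values given here, no measured pair isolates this change, so the expectation rests on compound 1 with its 8500 nM as the single anchor. The expected step of a 1.4-fold lower number from compound 1 to compound 3 (0.15 log units; within the scatter) in this assay is small, leaning slightly towards a lower number, and is not expected to go beyond the usual scatter. Compound 3 is estimated at 6000 nM with an expected range from 2500 nM to 12000 nM around that figure.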

Compound 3, half-maximal effective concentration: < 10000 nM
Compound 3: only a limit was reported; the forecaster's own chance of this, stated with the estimate: 25%; the middle value lies beyond the limit too.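

For the compounds shown here, for compound 3, < 10000 nM in this assay is a limit and not a number, and no step from compound 1 to compound 3 can be read from it. The compounds shown leave open whether 3,4-dihydroxyphenyl in place of 3,5-dihydroxyphenyl changes the reading at all, and in which direction.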